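The source may hold more compounds than are shown below. What is called first, only, known or untested is meant among the compounds shown, and "the series" means these compounds.

Measured so far:

compound 1, `Cc1oc(-c2ccccc2Cl)nc1CN1CCC(C(=O)NCCCN2C[C@H](C)C[C@H](C)C2)CC1`: 0.25 h
compound 2, `Cc1ccccc1-c1nc(CN2CCC(C(=O)NCCCN3CCCC(CC(C)C)C3)CC2)c(C)o1`: 0.0383 h
compound 3, `Cc1cccc(Cl)c1-c1nc(CN2CCC(C(=O)NCCCN3CCC(C)(C)CC3)CC2)c(C)o1`: 0.0733 h

These three compounds share one core and were all tested in an ADME assay on microsomes from liver (Rattus norvegicus) for metabolic stability, read by LC-MS, using NADPH, at 37 degrees C; a lower number here means that the compound disappears faster, a higher number that the compound lasts longer. Compound 1 stands at the top of the three numbers. Its nearest neighbour is compound 3, whose value in this assay is 0.0733 h, a gap that lies beyond the usual scatter. Compound 2 lies furthest away, with 0.0383 h, also beyond the scatter. So compound 1 is the longest-lasting of the three in this assay.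

The next compound, compound 4, is `Cc1cccc(-c2nc(CN3CCC(C(=O)NCCCN4C[C@H](C)C[C@H](C)C4)CC3)c(C)o2)c1`. It differs from compound 1 in one place: 3-methylphenyl in place of 2-chlorophenyl on an aromatic carbon. The 2-chlorophenyl leaves and a 3-methylphenyl enters on the aromatic carbon of the five-membered ring.

For the measured compounds named here, no direct step between measured compounds guides this change. Still, compound 2, which carries a methyl-bearing phenyl on the same part of the core, gives only 0.0383 h, well under compound 1. The expected step in this assay is therefore downward, a 2.1-fold lower number from compound 1 to compound 4 (0.32 log units; beyond the scatter), moderate in size but likely beyond the scatter. For compound 4 the expected half-life in this assay is 0.12 h, within a range from 0.04 h to 0.35 h.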

Compound 4, half-life: > 0.5 h
Compound 4 was reported as a limit; the forecaster's own chance of this, stated with the estimate: 5%; middle value at least 4.1-fold (0.61 log units) away from the limit.
By their numbers in this assay, from the lowest: compounds 2 and 3 (each within the scatter of the next); then compound 1. At a limit, above all of these: compound 4.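

In this assay, placing 3-methylphenyl instead of 2-chlorophenyl on the aromatic carbon of the five-membered ring gives an at least 2.0-fold higher number from compound 1 to compound 4 (0.30 log units; that floor lies within the scatter). For the compounds shown here, this is the first step that isolates this position, with the rest of compound 1 left unchanged, and it shows that a methyl-bearing phenyl here does not by itself bring a short half-life. Compound 4 is reported only as a limit, so this step gives a floor and not a true size, and that floor alone does not clear the usual scatter: the limit of > 0.5 h in this assay, at which 1 of the 4 values shown sits.

On these data alone, how long compound 4 actually lasts remains open, and so does how much of the change belongs to losing the chlorine and how much to gaining the methyl. As far as these compounds go, it is also open how this carbon would behave with a plain phenyl, a methoxyphenyl or a phenyl bearing a nitrile, and whether 3-methylphenyl would give a similar result with a different amine at the far end of the chain.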